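A trifluoromethylphenyl ketone at the limit of cytotoxicity

The compounds below may be only part of what the source reports. "The series", "measured", "known", "first", "only" and "open" are said of these compounds alone.

Compound 1 `COc1cc(-c2nnc3n2NC(c2ccco2)C(C(=O)c2ccccc2F)S3)cc(OC)c1OC` carries a 2-fluorophenyl on the carbonyl carbon of the shared core. In a functional assay on HepG2 cells (Homo sapiens) for cytotoxicity, read by MTT assay, with a stated time of 48 h (a lower number here means a stronger inhibitor, a higher number a weaker inhibitor), compound 1 reaches only the limit of the assay, > 100000 nM, and not a number. Compound 2 `COc1cc(-c2nnc3n2NC(c2ccco2)C(C(=O)c2ccc(Br)cc2)S3)cc(OC)c1OC` likewise returns only the limit, > 100000 nM. Within the data shown here, compound 3 `COc1cc(-c2nnc3n2NC(c2ccco2)C(C(=O)c2cccc4ccccc24)S3)cc(OC)c1OC` is the one member of the set with a measured number, 33900 nM. The two limits make the step that the two limits leave unreadable from compound 1 to compound 2, while the step of an at least 2.9-fold lower number from compound 1 to compound 3 (0.46 log units; beyond the scatter) and the step of an at least 2.9-fold lower number from compound 2 to compound 3 (0.46 log units; beyond the scatter) show that naphthalen-1-yl on the carbonyl carbon brings the number down to a readable value.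

Compound 4 `COc1cc(-c2nnc3n2NC(c2ccco2)C(C(=O)c2ccc(C(F)(F)F)cc2)S3)cc(OC)c1OC` differs from compound 1 as follows: 4-(trifluoromethyl)phenyl in place of 2-fluorophenyl on a carbonyl carbon. The closest comparison is compound 2, in which a substituted phenyl on the same carbon left the value at the limit, a position where (the limit of > 100000 nM in this assay, at which 2 of the 3 values shown sit). A change from compound 1 to compound 4 of this kind is therefore expected to give no step beyond the scatter in this assay, and compound 4 is most likely to sit at the limit again rather than at a number. Compound 4 is estimated at 120000 nM, with a range from 40000 nM to 400000 nM, which corresponds to an expected step that the limit leaves unreadable from compound 1 to compound 4.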

Compound 4, half-maximal inhibitory concentration: > 100000 nM
Compound 4 ended at the assay's limit (the forecaster's own chance of this, stated with the estimate: 65%); the middle value lies beyond the limit too.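

In this assay the new comparison is an at least 2.9-fold higher number from compound 3 to compound 4 (0.46 log units; beyond the scatter), so the readable value of compound 3 does not carry over to 4-(trifluoromethyl)phenyl on the carbonyl carbon. A third substituted phenyl now stands at the limit, and naphthalen-1-yl in compound 3 remains the only group here that goes against this, leaving the picture at this position as follows: the limit of > 100000 nM in this assay, at which 3 of the 4 values shown sit. The steps joining compound 4 to compound 1 and to compound 2 cannot be read, so any difference among these three compounds stays hidden, whether between the two groups in the para-free wording of their names or between bromo and trifluoromethyl on the aromatic carbon.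

The compounds shown leave open whether an amine or a carboxylic acid on the phenyl would bring the number away from the limit. They also leave open whether naphthalen-2-yl would keep a readable value like that of compound 3, and how much lower than that value any group on this carbonyl carbon could take the number.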